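Replacing Phenoxy with Chloro: Cytotoxicity Outlook for Compound 4

The source may report more compounds than this note shows. Statements on the series, on what has been measured and on what is new or still open speak of the compounds shown alone.

Three compounds sharing one core have been examined in an ADME assay on BJ cells (Homo sapiens) for cytotoxicity, read by CellTiter-Glo and resazurin assay, with a stated time of 72 h; on this read-out lower numbers stand for an effect already at smaller amounts and higher numbers for an effect only at larger amounts of compound. Compound 1 `CC(C)N(Cc1cccc(OCCCCCC(=O)O)c1)C(=O)c1ccc(-c2cccc(Oc3ccccc3)c2)cc1` gives > 18700 nM, which is a limit of the assay rather than a measured number. Compound 2 `CCOC(=O)CCCCCOc1cccc(CN(C(=O)c2ccc(-c3ccco3)cc2)C(C)C)c1` gives > 26000 nM, again a limit. Compound 3 `CCOC(=O)CCCCCOc1cccc(CN(C(=O)c2ccc(-c3cccc(Oc4ccccc4)c3)cc2)C(C)C)c1` gives > 19600 nM, once more a limit. Compound 3 therefore stands at one of three limits, alongside the limit of > 18700 nM in this assay, at which 1 of the 3 values shown sits, and (the limit of > 26000 nM in this assay, at which 1 of the 3 values shown sits), so none of the three can be ranked against the others. Among the measured compounds shown here, the single measured step, ethyl in place of hydrogen on an oxygen next to a carbonyl group, is a step that the two limits leave unreadable from compound 1 to compound 3, and its size cannot be read because both ends are limits.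

Compound 4 `CCOC(=O)CCCCCOc1cccc(CN(C(=O)c2ccc(-c3cccc(Cl)c3)cc2)C(C)C)c1` differs from compound 3 by chloro in place of phenoxy on an aromatic carbon. For the measured compounds named here, no measured step mirrors this exchange, and the only step available is unreadable, so no direction beyond the scatter can be expected. Compound 4 is estimated at about 30000 nM, with a range from 10000 nM to 100000 nM, and most likely reported again as a limit. The expected step is a step that the limit leaves unreadable from compound 3 to compound 4, within the scatter.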

Compound 4, half-maximal effective concentration: > 18400 nM
Compound 4: a limit, no number; the forecaster's own chance of this, stated with the estimate: 75%; the middle value does not contradict the limit.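

Compound 4 again gives only a limit of the assay, so its steps from compound 3 and from compound 2 cannot be read. In this assay the four compounds shown leave open the concentration at which any of them reaches its half-maximal effect.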